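A Methyl Step Repeated on a Second Core

The compounds below may be only part of what the source reports. "The series", "measured", "known", "first", "only" and "open" are said of these compounds alone.

Compound 1 `O=[N+]([O-])c1cc(-c2nnn(Cc3ccccc3)n2)cc([N+](=O)[O-])c1` and compound 2 `Cc1ccc(Cn2nnc(-c3cc([N+](=O)[O-])cc([N+](=O)[O-])c3)n2)cc1` share one core, while compound 3 `O=[N+]([O-])c1cc(-c2nnnn2Cc2ccccc2)cc([N+](=O)[O-])c1` is built from the same atoms joined differently; the difference between the two cores is not broken down here. In an ADME assay on CHO-K1 cells (Cricetulus griseus) for cytotoxicity, read by MTT assay, with a stated time of 24 h (a higher number here means a weaker inhibitor, a lower number a stronger inhibitor), compound 1 gives 150000 nM, compound 2 gives 200000 nM and compound 3 gives 18000 nM. Among the compounds with values here, the only change between the first two is methyl in place of hydrogen on an aromatic carbon and it made a 1.3-fold higher number from compound 1 to compound 2 (0.12 log units; within the scatter). Compound 3 has the lowest of the three numbers, and its gaps to compound 1 and to compound 2 both lie beyond the scatter.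

Compound 4 `Cc1ccc(Cn2nnnc2-c2cc([N+](=O)[O-])cc([N+](=O)[O-])c2)cc1` has not yet been measured. It differs from compound 3 by methyl in place of hydrogen on an aromatic carbon, the same change seen between the first two compounds, at the same place on the ring. Because the earlier change made a 1.3-fold higher number from compound 1 to compound 2 (0.12 log units; within the scatter), compound 4 is expected to show a step of a 1.2-fold higher number from compound 3 to compound 4 (0.09 log units; within the scatter) in this assay. Compound 4 is therefore estimated at 22000 nM, with a range from 9000 nM to 50000 nM.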

Compound 4, half-maximal inhibitory concentration: 28000 nM
Beside the measured number, compound 4's estimate is 1.3-fold (0.10 log units) below it; low and high end bracket the measured number.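

On the second core, going from benzyl to 4-methylbenzyl gave a 1.6-fold higher number from compound 3 to compound 4 (0.19 log units; within the scatter) in this assay, so the methyl step that left the number within the scatter on the first core did the same here. The two steps agree: the same change on two cores in this assay, a 1.3-fold higher number (0.12 log units; within the scatter) from compound 1 to compound 2 and a 1.6-fold higher number (0.19 log units; within the scatter) from compound 3 to compound 4, 1.2-fold (0.07 log units) apart, within the scatter of two such steps. This shows that, for these two pairs in this one cytotoxicity read-out, the change carried from one core to the other without a measurable effect on either, but two pairs cannot establish a rule for other cores, and steps this small do not show that the methyl has any real effect of a shared size.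

The compounds shown leave open whether a larger or differently natured group in place of that hydrogen, such as a methoxy group, a chlorine atom, an amine or a carboxylic acid, would also stay within the scatter on both cores. They also leave open whether a longer chain in place of the benzyl link would behave the same way on each core.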